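A few compounds are considered here, and "the series" means these few. Any claim that something is new, unique, unknown or untested is made for them only; others in the source may bear on it.

For the measured compounds named here, compound 1 `CN1CCN(CCCN(c2nc3cc(F)c(C(F)(F)F)cc3[nH]2)[C@@H]2CC[C@]3(c4ccc(C#N)cc4)C[C@H]23)CC1` is one of three compounds measured in a functional assay on the whole organism for inhibition, with Mus musculus as the target, with a stated time of 24 h, at a dose of 30 mg/kg by the oral route (a higher number here means more inhibition at the dose given (going by the name of the read-out), a lower number less inhibition), and in this assay compound 1 gives 94%, the second highest of the three numbers. Compound 2 `CN1CCN(CCCN(c2nc3cc(Cl)c(Cl)cc3[nH]2)[C@@H]2CC[C@]3(c4cccc(C#N)c4)C[C@@H]3C2)CC1` gives 97% in this assay, a number within the usual scatter of that of compound 1, so no order between the two can be claimed. Compound 3 `CS(=O)(=O)N1CCC(CN(c2nc3cc(F)c(F)cc3[nH]2)[C@@H]2CC[C@]3(c4cccc(C#N)c4)C[C@@H]3C2)CC1` gives 0%, a number far below that of compound 1, beyond the scatter. Compound 4 `CN1CCN(CCCN(c2nc3cc(F)c(Cl)cc3[nH]2)[C@@H]2CC[C@]3(c4ccc(C#N)cc4)C[C@H]23)CC1` is not yet measured; it differs from compound 1 by chloro in place of trifluoromethyl on an aromatic carbon. Going by the values given here, no pair of measured compounds isolates such a change. Since compound 1 and compound 2, which carry different substituents on the shared core, both give high inhibition, no step beyond the scatter is expected. Compound 4 is thus expected to give about 92%, between 75% and 100%, which would mean an expected step of a number 2 percentage points lower from compound 1 to compound 4 (within the scatter).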

Compound 4, a percentage reported as inhibition, in the whole organism at one dose (the size of the read-out at that dose, not a potency): 81%
Compound 4: middle estimate off by 11 percentage points, on the high side; the range from low to high includes it.
By their numbers in this assay, from the lowest: compound 3; then compound 4; then compounds 1 and 2 (each within the scatter of the next).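

The step of a number 13 percentage points lower from compound 1 to compound 4 (beyond the scatter) in this assay is the first change shown at this aromatic carbon, and it shows that the read-out is not indifferent to the group placed there, ortho to a fluoro group. Even so, with chloro at this carbon, compound 4 still gives 81% at the single dose tested. Nothing shown here accounts for this step.

From the compounds shown here alone, it remains open whether a methyl, a methoxy or an amine on this carbon would fall nearer to compound 1 or to compound 4. Also open, going by these compounds, is whether the step from trifluoromethyl to chloro would be the same with another group in place of the neighbouring fluoro group.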